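Working notes on an aromatic methoxy-to-hydroxy step

This account rests on a few compounds, and the source may have more. Where it says the series, first, only, none or still open, it means among the compounds named here.

Measured so far in a functional assay on MDA-MB-231 cells (Homo sapiens) for cytotoxicity, read by MTT assay; a higher number here means a weaker inhibitor, a lower number a stronger inhibitor:
compound 1 `COc1ccc(-c2cn(-c3ccc(OC(F)(F)F)cc3)nn2)cc1O` gives > 10000 nM, which is a limit of the assay.
compound 2 `COc1ccc(-c2cn(-c3cc(OC)c(OC)c(OC)c3)nn2)cc1OC` gives "not determined" (no result reported).
compound 3 `COc1ccc(-c2cn(-c3ccc(OC(F)(F)F)cc3)nn2)cc1OC` gives > 1000 nM, again only a limit.

Compound 3 and compound 1 share a core and differ in one place: hydrogen in place of methyl on an oxygen on an aromatic ring. The step that the two limits leave unreadable from compound 3 to compound 1 cannot be read in size because the limit of > 1000 nM in this assay, at which 1 of the 3 values shown sits, and the limit of > 10000 nM in this assay, at which 1 of the 3 values shown sits, are both limits, so it is not known whether the change helped, hurt or left potency unchanged. Compound 2 carries a second core; the difference between the core of compound 2 and the core of compound 3 is not broken down here. For compound 2 no number exists in this assay, only the statement that it was not determined.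

Compound 4 `COc1cc(-c2cn(-c3cc(OC)c(OC)c(OC)c3)nn2)ccc1O` is not yet measured. It stands to compound 2 as compound 1 stands to compound 3: hydrogen in place of methyl on an oxygen on an aromatic ring. The place of the change is the same in wording in both pairs, so the same change is made on two different cores. The size of the step from compound 2 to compound 4 in this assay cannot be expected from the earlier pair, since that step is unreadable and compound 2 itself has no value. With two of three values shown sitting at limits, compound 4 is expected to come out weak and most likely at a limit as well; the estimate for compound 4 is 20000 nM, within 3000 nM to 100000 nM, and this rests only on the limits of compound 1 and compound 3 in this assay.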

Compound 4, half-maximal inhibitory concentration: > 10000 nM
Compound 4 was reported as a limit; the forecaster's own chance of this, stated with the estimate: 80%; the middle value is on the limit's open side.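

No new step can be read between compound 2 and compound 4: compound 2 has no numeric result in this assay. In this assay compound 4 gives > 10000 nM, which is a limit and not a number. The compounds shown leave open whether the change from methoxy to hydroxy helps, hurts or leaves potency unchanged on either core.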